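Nitro for hydrogen in a series at its limit

The source may hold more compounds than are shown below. What is called first, only, known or untested is meant among the compounds shown, and "the series" means these compounds.

Measured in a functional assay on MCF7 cells (Homo sapiens) for antiproliferative activity, read by MTT assay, with a stated time of 72 h (on this read-out higher numbers stand for weaker inhibition and lower numbers for stronger inhibition), as follows
compound 1 `COc1cc(-c2ncnn2-c2cccc(F)c2)cc(OC)c1OC` gives > 10000 nM (a limit)
compound 2 `COc1cc(-c2ncnn2-c2cccc(N)c2)cc(OC)c1OC` gives > 10000 nM (a limit)
compound 3 `COc1cc(-c2ncnn2-c2ccccc2)cc(OC)c1OC` gives > 10000 nM (a limit)

Compound 3 stands at > 10000 nM, which is a limit of the assay and not a number. The other two measured compounds also stop at a limit, so compound 3 has no readable rank among them. Going by the values given here, the series so far amounts to the limit of > 10000 nM in this assay, at which 3 of the 3 values shown sit, and no more.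

Compound 4 `COc1cc(-c2ncnn2-c2cccc([N+](=O)[O-])c2)cc(OC)c1OC` carries nitro in place of hydrogen on an aromatic carbon, meta to a large group: nitro in place of hydrogen on an aromatic carbon. The nearest measured changes also swap a group on an aromatic carbon. They are a step that the two limits leave unreadable from compound 1 to compound 3 and a step that the two limits leave unreadable from compound 2 to compound 3, and a step that the two limits leave unreadable from compound 1 to compound 2 adds nothing further. None of them has a readable size, so they support no expected direction and no expected step beyond the scatter in this assay. The expected change is a step that the limit leaves unreadable from compound 3 to compound 4. For compound 4 the estimate is 20000 nM, and the expected range runs from 5000 nM to 80000 nM.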

Compound 4, half-maximal inhibitory concentration: > 10000 nM
Compound 4 was reported as a limit; the forecaster's own chance of this, stated with the estimate: 85%; the middle value is on the limit's open side.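

In this assay compound 4 gives > 10000 nM, which is a limit of the assay and not a number. Going by these compounds alone, no step between compound 4 and compound 1, compound 2 or compound 3 can be read: the limit of > 10000 nM in this assay, at which 4 of the 4 values shown sit. The compounds shown leave open how these four rank and whether any group on this aromatic carbon gives a readable value in this assay.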